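Trading trifluoromethoxy for dimethylamino in a cytotoxicity series

The source may report more compounds than this note shows. Statements on the series, on what has been measured and on what is new or still open speak of the compounds shown alone.

Of the compounds shown here, two have been tested so far in a functional assay on HCT-15 cells (Homo sapiens) for cytotoxicity, read by MTT assay, with a stated time of 2 days; on this read-out lower numbers stand for stronger inhibition and higher numbers for weaker inhibition. Among the compounds with values here, compound 2 `CCN(CC)c1ccc2nc(-c3ccccc3OC(F)(F)F)[nH]c(=O)c2c1` gives 1710 nM, the only true number available. Compound 1 `Cc1ccc2nc(-c3ccccc3N(C)C)[nH]c(=O)c2c1` reads > 50000 nM, which is a limit of the assay and not a number. Compound 3 `CCN(CC)c1ccc2nc(-c3ccccc3N(C)C)[nH]c(=O)c2c1` keeps compound 2 intact except for one exchange: dimethylamino in place of trifluoromethoxy on an aromatic carbon, ortho to a large group (dimethylamino in place of trifluoromethoxy on an aromatic carbon). Within the data shown here, no measured pair isolates this exchange in this assay. Among the measured compounds shown here, compound 1, the only tested compound bearing dimethylamino, gives > 50000 nM, again a limit, and it differs from compound 3 elsewhere as well. A moderate weakening is therefore expected rather than a gain, with the expected change being a 2.3-fold higher number from compound 2 to compound 3 (0.37 log units; beyond the scatter). The estimated value for compound 3 is 4000 nM, within an expected range of 1000 nM to 20000 nM.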

Compound 3, half-maximal inhibitory concentration: 4200 nM
Estimate against measurement, compound 3: 1.1-fold (0.02 log units) below; measured number inside the range.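

In this assay, the exchange of trifluoromethoxy for dimethylamino on this aromatic carbon can now be read on its own, and it gives a 2.5-fold higher number from compound 2 to compound 3 (0.39 log units; beyond the scatter), so dimethylamino keeps a measurable value in the low range of this series instead of the reading seen for compound 1. Compound 1 stands at a limit of the assay and not at a number: the limit of > 50000 nM in this assay, at which 1 of the 3 values shown sits. With dimethylamino held constant, diethylamino in place of methyl on an aromatic carbon gives an at least 11-fold lower number from compound 1 to compound 3 (1.07 log units; beyond the scatter), a large step whose true size the limit leaves unknown, and this shows that the loss in compound 1 does not follow from dimethylamino alone.

As far as these compounds go, it remains open how a methoxy group, a chlorine atom or a pyrrolidine ring on the same aromatic carbon would read against trifluoromethoxy. From the compounds shown here alone, it is equally open whether a longer chain on the amine, such as dipropylamino in place of diethylamino, would lower the number further.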